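Working notes: from compound 2 to compound 3

The source may report more compounds than this note shows. Statements on the series, on what has been measured and on what is new or still open speak of the compounds shown alone.

Compound 1 `O=C(Nc1ccccc1)Nc1cccc(Nc2nccc(Nc3ccc4cn[nH]c4c3)n2)c1`: 8200 nM
Compound 2 `O=C(Nc1ccccc1)Nc1cccc(Nc2nccc(Nc3ccc4cc[nH]c4c3)n2)c1`: 3200 nM

Of the two compounds measured in a functional assay on HepG2 cells (Homo sapiens) for inhibition, read by fluorescence and resazurin assay, with a stated time of 72 h (on this read-out lower numbers stand for stronger inhibition and higher numbers for weaker inhibition), compound 2 holds the lower number. Compound 3 `Cc1c2ccc(Nc3ccnc(Nc4cccc(NC(=O)Nc5ccccc5)c4)n3)cc2nn1C` carries a single change from it: 2,3-dimethyl-2H-indazol-6-yl in place of 1H-indol-6-yl on a nitrogen on an aromatic ring. Within the data shown here, only one measured step bears on this place, a 2.6-fold lower number from compound 1 to compound 2 (0.41 log units; beyond the scatter), a modest step beyond the scatter with 1H-indol-6-yl in place of 1H-indazol-6-yl. Among the measured compounds shown here, no measured compound carries 2,3-dimethyl-2H-indazol-6-yl, so the reading is loose. A modest move to a higher number is expected in this assay, a 1.6-fold higher number from compound 2 to compound 3 (0.19 log units; within the scatter). Compound 3 is estimated at 5000 nM, with an expected range of 1800 nM to 14000 nM.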

Compound 3, half-maximal inhibitory concentration: 2400 nM
Compound 3: middle estimate off by 2.1-fold (0.32 log units), on the high side, within the range that was stated.
By their numbers in this assay, from the lowest: compounds 3 and 2 (each within the scatter of the next); then compound 1.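

The step of a 1.3-fold lower number from compound 2 to compound 3 (0.12 log units; within the scatter) does not separate 2,3-dimethyl-2H-indazol-6-yl from 1H-indol-6-yl at this place, although the entering group has no hydrogen-bond donor. Against 1H-indazol-6-yl, the same group gives a 3.4-fold lower number from compound 1 to compound 3 (0.53 log units; beyond the scatter) and so stands clear of the scatter. No available evidence gives a reason for either step.

The compounds shown leave open how each of the two methyl groups contributes, since no indazol-6-yl here carries only one. They also leave open how an aminomethyl or carboxylic acid substituent on this ring would read out.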